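Swapping the Para Group: Methyl to Trifluoromethyl

The source may report more compounds than this note shows. Statements on the series, on what has been measured and on what is new or still open speak of the compounds shown alone.

Compound 1 `Cc1cc(NC(=O)Cn2nnc(-c3ccc(F)cc3)n2)n(C2CCCCC2)n1` gives 92% in an assay on HEK293 cells for activation of Kir3.1/Kir3.2 (Homo sapiens), read by thallium flux; a higher number here means a larger maximal response, a lower number a smaller maximal response.
Compound 2 `Cc1cc(NC(=O)Cn2nnc(-c3ccc(F)c(F)c3)n2)n(C2CCCCC2)n1` gives 93% in this assay.
Compound 3 `Cc1ccc(-c2nnn(CC(=O)Nc3cc(C)nn3C3CCCCC3)n2)cc1` gives 86% in this assay.

All three share one core and differ only in the group on the outer six-membered ring. Compound 3 carries the 4-methylphenyl; its value sits close to the other two, since a number 6 percentage points lower from compound 1 to compound 3 (within the scatter) and a number 7 percentage points lower from compound 2 to compound 3 (within the scatter), so no ranking among the three is justified.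

Compound 4 `Cc1cc(NC(=O)Cn2nnc(-c3ccc(C(F)(F)F)cc3)n2)n(C2CCCCC2)n1` keeps that core and differs from compound 3 by trifluoromethyl in place of methyl on an aromatic carbon.

Among the compounds with values here, the steps that bear on this change are those that also swapped a group at this place: a number 6 percentage points lower from compound 1 to compound 3 (within the scatter), and the related a number 7 percentage points lower from compound 2 to compound 3 (within the scatter). Adding a second fluoro, a number 1 percentage points higher from compound 1 to compound 2 (within the scatter), also moved nothing of note. Every swap so far left the maximal response where it was, so the expected step here is a number 4 percentage points higher from compound 3 to compound 4 (within the scatter).

For compound 4 the estimate in this assay is 90%, expected to fall between 78% and 100%.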

Compound 4, largest response reached (Emax), in percent of the reference or control that the assay uses: 94%
Estimate against measurement, compound 4: 4 percentage points below; the range from low to high includes it.
By their numbers in this assay, from the lowest: compounds 3, 1, 2 and 4 (each within the scatter of the next).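

Four heavy atoms in place of one at this spot, para to a large group, still give a step inside the scatter in this assay: a number 8 percentage points higher from compound 3 to compound 4 (within the scatter). The same holds when trifluoromethyl is set against the other two groups, with a number 2 percentage points higher from compound 1 to compound 4 (within the scatter) and a number 1 percentage points higher from compound 2 to compound 4 (within the scatter), so the maximal responses of all four compounds cannot be told apart, and none of the groups shown here stands out. Nothing at hand explains why these different groups give such similar maximal responses.

Still open, going by these compounds, is whether a group of another kind on this ring carbon, such as an amine, a carboxylic acid or a longer chain, would give a response outside the scatter. All four compounds also share the rest of the core, so these values say nothing about changes elsewhere in the molecule.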